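A few compounds are considered here, and "the series" means these few. Any claim that something is new, unique, unknown or untested is made for them only; others in the source may bear on it.

Compound 1, `CN1CCN(C/C=C/C(=O)Nc2cc3c(N4CCc5ccccc54)ncnc3cc2O[C@@H]2CCOC2)CC1`, in a functional assay on MCF7 cells (Homo sapiens) for antiproliferative activity, read by MTT assay, with a stated time of 72 h (a higher number here means a weaker inhibitor, a lower number a stronger inhibitor), gives 5350 nM.
Compound 2, `O=C(/C=C/CN1CCC(CO)CC1)Nc1cc2c(N3CCc4ccccc43)ncnc2cc1O[C@@H]1CCOC1`, in this assay gives 4690 nM.
Compound 3, `COc1cc2ncnc(N3CCCc4ccccc43)c2cc1NC(=O)/C=C/CN1CCN(C)CC1`, in this assay gives 8560 nM.

Compound 1 and compound 2 share one core and differ in a single group: 4-(hydroxymethyl)piperidin-1-yl in place of 4-methylpiperazin-1-yl on a saturated chain carbon bound to a double-bonded chain carbon. The step that this change made in this assay is a 1.1-fold lower number from compound 1 to compound 2 (0.06 log units; within the scatter), so the two values sit within the usual scatter of each other and no real shift can be claimed from this pair.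

Compound 3 carries a different core. How its core differs from that of compound 1 is not broken down here. Its value in this assay sits within the scatter of both compound 1 and compound 2.

Compound 4, `COc1cc2ncnc(N3CCCc4ccccc43)c2cc1NC(=O)/C=C/CN1CCC(CO)CC1`, has not yet been measured. It stands to compound 3 as compound 2 stands to compound 1: 4-(hydroxymethyl)piperidin-1-yl in place of 4-methylpiperazin-1-yl on a saturated chain carbon bound to a double-bonded chain carbon. The place of the change is described in the same words for both pairs, so this is the same change made on a second core.

The expectation for compound 4 rests on the measured pair: since the change gave a 1.1-fold lower number from compound 1 to compound 2 (0.06 log units; within the scatter), the estimated step from compound 3 to compound 4 is a 1.1-fold lower number from compound 3 to compound 4 (0.04 log units; within the scatter), a shift that stays within the scatter. On that basis compound 4 is expected to give about 7800 nM in this assay, with an estimated range from 4000 nM to 15000 nM.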

Compound 4, half-maximal inhibitory concentration: 5740 nM
Compound 4: the middle estimate sits 1.4-fold (0.13 log units) above what was measured, within the range that was stated.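

On the second core, 4-(hydroxymethyl)piperidin-1-yl in place of 4-methylpiperazin-1-yl gives a 1.5-fold lower number from compound 3 to compound 4 (0.17 log units; within the scatter) in this assay and so, like the step on the first core, counts as no real shift. Set side by side, the two steps do not differ: the same change on two cores in this assay, a 1.1-fold lower number (0.06 log units; within the scatter) from compound 1 to compound 2 and a 1.5-fold lower number (0.17 log units; within the scatter) from compound 3 to compound 4, 1.3-fold (0.12 log units) apart, within the scatter of two such steps

The change therefore behaves alike on both cores in this narrow sense: on neither core can a real shift be claimed, and swapping one of these two groups for the other leaves the numbers within the usual scatter of repeated measurements. This does not show that the two cores would respond alike to a change with a real effect, since two steps that are both within the scatter cannot test that, and it says nothing about cores beyond these two.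

The compounds shown leave open how a plain piperidine, a morpholine or a dimethylamino group would read on the same saturated chain carbon bound to a double-bonded chain carbon. They also leave open whether the hydroxymethyl group itself matters, which a comparison with a methyl group or a carboxylic acid in its place could begin to answer.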